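Removing the last methyl group from compound 3

The source may hold more compounds than are shown below. What is called first, only, known or untested is meant among the compounds shown, and "the series" means these compounds.

Compound 3 `CN1CCC2=CC[C@H](O)C[C@@H]21` gives 300000 nM in an assay on HEK293 cells for displacement of a labelled ligand from Neuronal acetylcholine receptor; alpha4/beta2 (Rattus norvegicus), with a stated time of 4 h; a lower number here means a stronger inhibitor, a higher number a weaker inhibitor; compound 2 `CO[C@H]1CC=C2CCN[C@H]2C1` gives 300000 nM, level with compound 3 at the digits shown, and both stand far behind compound 1 `CO[C@H]1CC=C2CCN(C)[C@H]2C1`, which gives 3400 nM. Compound 4 `O[C@H]1CC=C2CCN[C@H]2C1` differs from compound 3 by hydrogen in place of methyl on an amine nitrogen in a ring. The same change on compound 1 gave an 88-fold higher number from compound 1 to compound 2 (1.95 log units; beyond the scatter), and the change that leads from compound 1 to compound 3 gave an 88-fold higher number from compound 1 to compound 3 (1.95 log units; beyond the scatter). Both removals of a methyl group weakened binding by a large margin, so compound 4, carrying neither methyl group, is expected to bind no better than compound 3 and probably worse, with the step estimated as a 3.3-fold higher number from compound 3 to compound 4 (0.52 log units; beyond the scatter). Compound 4 is therefore expected at 1000000 nM, within 300000 nM to 10000000 nM, where the assay may report only a limit.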

Compound 4, inhibition constant: > 300000 nM
Compound 4: no number, only a limit; the forecaster's own chance of this, stated with the estimate: 60%; the middle value does not contradict the limit.
By their numbers in this assay, from the lowest: compound 1; then compounds 2 and 3 (each within the scatter of the next).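

Compound 4 gives only a limit in this assay, > 300000 nM, so the sizes of its steps cannot be read. What it adds is that hydrogen in place of methyl on an amine nitrogen in a ring gives a number no lower from compound 3 to compound 4 (the limit leaves the size open), and hydrogen in place of methyl on an oxygen on a saturated carbon gives a number no lower from compound 2 to compound 4 (the limit leaves the size open). The first of these changes does not bring back measurable binding on the core of compound 3, while the size of any further loss stays hidden: the same change on two cores in this assay, an 88-fold higher number (1.95 log units; beyond the scatter) from compound 1 to compound 2 and a number no lower (the limit leaves the size open) from compound 3 to compound 4; the limit leaves it open whether they differ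

The compounds shown leave open how ethyl on that nitrogen would compare with methyl. They also leave open how a longer chain on the oxygen would compare with the methyl of compound 1.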